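Swapping Triazoles on the Aryl Urea of Compound 1

The compounds below may be only part of what the source reports. "The series", "measured", "known", "first", "only" and "open" are said of these compounds alone.

The compounds are compared in a functional assay on a cell-free system (plasma) with sterol O-acyltransferase, Soat (Rattus norvegicus) as the target; a lower number here means that less compound is needed, a higher number that more compound is needed for the effect. Compound 1 `Cc1cc(C)c(NC(=O)N(Cc2ccc(-c3n[nH]c(C)n3)cc2)C2CCCCCC2)c(C)c1` gives in this assay only a limit of the assay and not a number, > 1 mg/kg, and its value is the one that sits at the limit of > 1 mg/kg in this assay, at which 1 of the 3 values shown sits. Going by the values given here, compound 2 `COc1ccc(CN(Cc2cccc(-c3cc[nH]n3)c2)C(=O)Nc2c(SC)cc(C)nc2SC)cc1` also returns a limit in this assay, < 0.1 mg/kg, the one value at the limit of < 0.1 mg/kg in this assay, at which 1 of the 3 values shown sits. Among the compounds with values here, compound 3 `CSc1cc(C)nc(SC)c1NC(=O)N(Cc1cccc(-c2cnn(C)c2)c1)C1CCCCCC1` returns in this assay the limit > 0.1 mg/kg, the one value at the limit of > 0.1 mg/kg in this assay, at which 1 of the 3 values shown sits. No two of these compounds differ in a single place, so no measured step can be drawn between them, and compound 1 is known only as a limit. Compound 4 `Cc1cc(C)c(NC(=O)N(Cc2ccc(-n3nccn3)cc2)C2CCCCCC2)c(C)c1` differs from compound 1 in one place: 2H-1,2,3-triazol-2-yl in place of 5-methyl-1H-1,2,4-triazol-3-yl on an aromatic carbon. Within the data shown here, with no measured step of this kind to draw on, the change from compound 1 to compound 4 is expected to stay within the scatter, the step being estimated as a step that the limit leaves unreadable from compound 1 to compound 4. Compound 4 is thus expected to give about 2 mg/kg in this assay, with a plausible range from 0.7 mg/kg to 8 mg/kg.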

Compound 4, dose for half-maximal effect: > 1 mg/kg
Compound 4: no number, only a limit (the forecaster's own chance of this, stated with the estimate: 60%); the middle value lies beyond the limit too.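

Compound 1 and compound 4 sit at the same limit of the assay, so no step can be read between them: the limit of > 1 mg/kg in this assay, at which 2 of the 4 values shown sit.

Left open in this assay is how far each compound lies past that limit, and so whether 2H-1,2,3-triazol-2-yl and 5-methyl-1H-1,2,4-triazol-3-yl differ at all.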